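Dithiocarbamate butenolides: pyrrolidine in place of cyclopropylamine

A few compounds are considered here, and "the series" means these few. Any claim that something is new, unique, unknown or untested is made for them only; others in the source may bear on it.

Measured compounds:
compound 1 `Cc1ccc(NC(=S)SCC2=CCOC2=O)cc1`: 97400 nM
compound 2 `O=C1OCC=C1CSC(=S)NC1CC1`: 94900 nM
compound 3 `O=C1OCC=C1CSC(=S)N1CCOCC1`: 60300 nM

All three share the butenolide-linked dithiocarbamate core and differ only in the group on the thiocarbonyl carbon. In a functional assay on MCF7 cells (Homo sapiens) for antiproliferative activity, read by MTT assay, with a stated time of 72 h (a lower number here means a stronger inhibitor, a higher number a weaker inhibitor), compound 1 gives 97400 nM and compound 3 gives 60300 nM; in this assay compound 2 gives 94900 nM, the second highest of the three numbers, with its gap to compound 1 within the scatter and its gap to compound 3 also within the scatter. Among the compounds with values here, nothing so far separates a secondary from a tertiary dithiocarbamate nitrogen beyond the noise.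

Compound 4 `O=C1OCC=C1CSC(=S)N1CCCC1` has not yet been run. It differs from compound 2 by pyrrolidin-1-yl in place of cyclopropylamino on a thiocarbonyl carbon. Within the data shown here, no measured pair isolates this change. With compound 3, which carries a comparable tertiary ring, giving 60300 nM and compound 2 giving 94900 nM, only a small step is expected, if any, in this assay.

Compound 4 is therefore expected to give 70000 nM in this assay, within 25000 nM to 200000 nM. The step of a 1.4-fold lower number from compound 2 to compound 4 (0.13 log units; within the scatter) that this estimate implies is expected to stay within the scatter.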

Compound 4, half-maximal inhibitory concentration: 56400 nM
For compound 4 the middle estimate is 1.2-fold (0.09 log units) above the measured one, and the stated range covers the measured number.
By their numbers in this assay, from the lowest: compounds 4, 3, 2 and 1 (each within the scatter of the next).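

In this assay, within the data shown here, pyrrolidin-1-yl in place of cyclopropylamino on a thiocarbonyl carbon gives the first step that isolates a change at this position: a 1.7-fold lower number from compound 2 to compound 4 (0.23 log units; within the scatter). In this single pair, the move from a three-membered ring of carbon only with 1 hydrogen-bond donor to a five-membered ring with 0 hydrogen-bond donors leaves the number within the scatter. Nothing measured on these compounds bears on the origin of this small step.

The compounds shown leave open whether any group on the thiocarbonyl carbon can move the number beyond the scatter, since each of the four values lies within the scatter of the next. A piperazin-1-yl or a diethylamino group in this place would test that further, and the shared core remains unvaried.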